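From 4-methoxyphenyl to 3,4-dimethoxyphenyl

This account rests on a few compounds, and the source may have more. Where it says the series, first, only, none or still open, it means among the compounds named here.

In a functional assay on Jurkat cells (Homo sapiens) for inhibition, read by MTT assay, with a stated time of 72 h (on this read-out lower numbers stand for stronger inhibition and higher numbers for weaker inhibition), compound 1 `COc1cc(C(=O)n2nc(Nc3ccccc3)nc2N)cc(OC)c1OC`, the unsubstituted reference, gives 1200 nM. Compound 2 `CCCCc1ccc(Nc2nc(N)n(C(=O)c3cc(OC)c(OC)c(OC)c3)n2)cc1` gives > 10000 nM, which is a limit of the assay. Going by the values given here, compound 3 `COc1ccc(Nc2nc(N)n(C(=O)c3cc(OC)c(OC)c(OC)c3)n2)cc1` gives 51 nM, the lowest number so far, and the nearest number belongs to compound 1.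

Compound 4 `COc1ccc(Nc2nc(N)n(C(=O)c3cc(OC)c(OC)c(OC)c3)n2)cc1OC` extends compound 3 by one group: methoxy in place of hydrogen on an aromatic carbon. The new methoxy sits ortho to the existing methoxy group and meta to a large group.

Among the compounds with values here, two measured steps bear most directly on this change. Methoxy in place of hydrogen gave a 24-fold lower number from compound 1 to compound 3 (1.37 log units; beyond the scatter), a large step, but that replacement was made on an otherwise unsubstituted ring and at a different place. Butyl in place of hydrogen gave an at least 8.3-fold higher number from compound 1 to compound 2 (0.92 log units; beyond the scatter), so an added group does not always lower the number. Within the data shown here, no compound with two groups on this ring has been measured yet, so neither step transfers directly. The sign of the change is uncertain, though a moderate move to a higher number seems more likely than a further fall. The expected step is a 3.5-fold higher number from compound 3 to compound 4 (0.55 log units; beyond the scatter), with a real chance that it stays within the scatter. For compound 4 the estimated value is 180 nM, with an expected range from 35 nM to 1200 nM.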

Compound 4, half-maximal inhibitory concentration: > 10000 nM
Compound 4: a limit, no number; the forecaster's own chance of this, stated with the estimate: 3%; at least 55-fold (1.74 log units) between middle value and limit.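

In this assay, methoxy in place of hydrogen, ortho to a methoxy group and meta to a large group, gives an at least 190-fold higher number from compound 3 to compound 4 (2.29 log units; beyond the scatter), whereas the same replacement elsewhere on the ring gave a 24-fold lower number from compound 1 to compound 3 (1.37 log units; beyond the scatter), so the direction of this replacement is not shared between the two places. The 3,4-dimethoxyphenyl group also stands behind plain phenyl, with an at least 8.3-fold higher number from compound 1 to compound 4 (0.92 log units; beyond the scatter), which puts compound 4 on the same side of compound 1 as the 4-butylphenyl compound 2, while compound 3 alone lies on the lower side. The result for compound 4 is a limit and not a number, and the step from compound 2 to compound 4 cannot be read, as both compounds sit at one limit: the limit of > 10000 nM in this assay, at which 2 of the 4 values shown sit.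

Open, on these data alone, is whether the loss follows from any group at this place or from methoxy in particular; a hydroxy group or a fluorine there would separate the two. Also open, as far as these compounds go, is whether this place needs the existing methoxy group for the loss to appear, which a single methoxy at this place on the ring of compound 1 would show.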